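Changing the Ring on the Carbonyl Carbon

The source may report more compounds than this note shows. Statements on the series, on what has been measured and on what is new or still open speak of the compounds shown alone.

Compound 1 `CCCn1c(NC(=O)c2ccc3ccccc3n2)nc2cc(C(N)=O)cc(OC)c21` gives > 100000 nM in an assay for activation of interferon regulatory factor 3 (Homo sapiens), read by a luciferase reporter, with a stated time of 20 h (a lower number here means that less compound is needed, a higher number that more compound is needed for the effect), which is a limit of the assay and not a number.
Compound 2 `CCCn1c(NC(=O)c2nccc3ccccc23)nc2cc(C(N)=O)cc(OC)c21` gives > 100000 nM in this assay, again only a limit.
Compound 3 `CCCn1c(NC(=O)c2cccnn2)nc2cc(C(N)=O)cc(OC)c21` gives > 100000 nM in this assay, again only a limit.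

All three values sit at the same limit (the limit of > 100000 nM in this assay, at which 3 of the 3 values shown sit), so compound 3 stands level with the other two and no order among them can be read. The steps a step that the two limits leave unreadable from compound 1 to compound 2, a step that the two limits leave unreadable from compound 1 to compound 3 and a step that the two limits leave unreadable from compound 2 to compound 3 are accordingly of unreadable size. Compound 4 `CCCn1c(NC(=O)c2ccnn2CC)nc2cc(C(N)=O)cc(OC)c21` differs from compound 3 by 1-ethyl-1H-pyrazol-5-yl in place of pyridazin-3-yl on a carbonyl carbon. For the measured compounds named here, since no measured step gives a readable size, the expected step in this assay is a number no higher from compound 3 to compound 4 (the limit leaves the size open), most likely ending again at a limit. Compound 4 is estimated at 100000 nM, between 30000 nM and 300000 nM.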

Compound 4, half-maximal effective concentration: > 100000 nM
Compound 4: a limit, no number; the forecaster's own chance of this, stated with the estimate: 80%; the middle value sits exactly at the limit.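

Compound 4 sits at the same assay limit as compound 1, compound 2 and compound 3, so none of its steps to them can be read: the limit of > 100000 nM in this assay, at which 4 of the 4 values shown sit. The compounds shown leave open which ring on the carbonyl carbon, if any, would give a measurable value in this assay.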